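Amide nitrogen substituent and whole-organism ear inhibition

The source may hold more compounds than are shown below. What is called first, only, known or untested is meant among the compounds shown, and "the series" means these compounds.

Measured so far:
compound 1 `CCNC(=O)c1cc(-c2ccc(F)cc2F)ccc1OC(C)=O` gives 5.38% in a functional assay on the whole organism (Ear) for inhibition, with Mus musculus as the target, at a dose of 40 mg/kg by the oral route; on this read-out higher numbers stand for more inhibition at the one dose given (going by the name of the read-out) and lower numbers for less inhibition
compound 2 `CC(=O)Oc1ccc(-c2ccc(F)cc2F)cc1C(=O)NCc1ccccc1` gives 34.1% in this assay

Compound 2 stands higher of the two, with a number 28.7 percentage points higher from compound 1 to compound 2 (beyond the scatter). Compound 3 `CC(=O)Oc1ccc(-c2ccc(F)cc2F)cc1C(=O)Nc1ccc(Cl)cc1` is not yet measured; it differs from compound 2 by 4-chlorophenyl in place of benzyl on an amide-type nitrogen. Among the compounds with values here, the one measured step concerns the group on the saturated chain carbon bound to the amide nitrogen, not a ring placed directly on that nitrogen, so it bears on compound 3 only loosely. A value near that of compound 2 is expected, with wide uncertainty, giving an estimated step of a number 0.9 percentage points higher from compound 2 to compound 3 (within the scatter). Compound 3 is estimated at 35%, with a range from 10% to 60%.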

Compound 3, a percentage reported as inhibition, in the whole organism at one dose (the size of the read-out at that dose, not a potency): 0%
Compound 3: middle estimate off by 35 percentage points, on the high side; the whole stated range lies above it.
By their numbers in this assay, from the lowest: compounds 3 and 1 (each within the scatter of the next); then compound 2.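

In this assay, 4-chlorophenyl in place of benzyl on the amide-type nitrogen gives a number 34.1 percentage points lower from compound 2 to compound 3 (beyond the scatter) even though both groups have the same heavy-atom count, so a ring-bearing group at this position does not by itself carry the response. Against ethyl, the same 4-chlorophenyl gives a number 5.4 percentage points lower from compound 1 to compound 3 (within the scatter) and leaves only compound 2 clear of the other two. Nothing on hand bears on the reason for this difference.

On these data alone, whether unsubstituted phenyl would behave like compound 2 or compound 3 remains open. So does the effect of a longer chain such as phenethyl on the amide-type nitrogen.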